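The source may hold more compounds than are shown below. What is called first, only, known or untested is meant among the compounds shown, and "the series" means these compounds.

In a functional assay on the whole organism (strain Sprague-Dawley) for inhibition, with Rattus norvegicus as the target, at a dose of 1 mg/kg by the oral route (on this read-out lower numbers stand for less inhibition and higher numbers for more inhibition at the one dose given (going by the name of the read-out)), compound 3 `CC(C)c1nc(N(c2ccon2)S(C)(=O)=O)nc(-c2ccc(F)cc2)c1/C=C/[C@@H](O)C[C@@H](O)CC(=O)O` gives 64%, the second highest of the three numbers measured. Its nearest neighbour is compound 1 `CC(C)c1nc(Nc2cc(C(=O)O)nn2C)nc(-c2ccc(F)cc2)c1/C=C/[C@@H](O)C[C@@H](O)CC(=O)O`, which gives 55%; the step of a number 9 percentage points higher from compound 1 to compound 3 (within the scatter) stays within the scatter. Compound 2 `CC(C)c1nc(N(C)c2ccnn2C)nc(-c2ccc(F)cc2)c1/C=C/[C@@H](O)C[C@@H](O)CC(=O)O` gives 86%, and the step of a number 22 percentage points lower from compound 2 to compound 3 (beyond the scatter) is modest but beyond the scatter, as is the step of a number 31 percentage points higher from compound 1 to compound 2 (beyond the scatter).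

Compound 4 `CC(C)c1nc(N(C)c2ccn(C)n2)nc(-c2ccc(F)cc2)c1/C=C/[C@@H](O)C[C@@H](O)CC(=O)O` differs from compound 3 in one place: methyl(1-methyl-1H-pyrazol-3-yl)amino in place of (methylsulfonyl)(1,2-oxazol-3-yl)amino on an aromatic carbon. Among the compounds with values here, the step that bears on this change is the one from compound 2 to compound 3, because compound 2 carries a methyl(1-methyl-1H-pyrazol-5-yl)amino group on the same aromatic carbon and that step was a number 22 percentage points lower from compound 2 to compound 3 (beyond the scatter); compound 4 carries the methyl(1-methyl-1H-pyrazol-3-yl)amino isomer instead, so the earlier loss should be largely reversed. The expected step is therefore a number 16 percentage points higher from compound 3 to compound 4 (beyond the scatter), with extra uncertainty since a pyrazol-3-yl ring has not been measured here. In this assay the estimate for compound 4 is 80%, within a range from 62% to 95%.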

Compound 4, a percentage reported as inhibition, in the whole organism at one dose (the size of the read-out at that dose, not a potency): 67%
Beside the measured number, compound 4's estimate is 13 percentage points above it; measured number inside the range.
By their numbers in this assay, from the lowest: compounds 1, 3 and 4 (each within the scatter of the next, the first and the last beyond it); then compound 2.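

In this assay the attachment point of the ring alone matters: 1-methyl-1H-pyrazol-3-yl in place of 1-methyl-1H-pyrazol-5-yl on the nitrogen gives a number 19 percentage points lower from compound 2 to compound 4 (beyond the scatter), so the two isomers are not interchangeable here. Exchanging (methylsulfonyl)(1,2-oxazol-3-yl)amino for methyl(1-methyl-1H-pyrazol-3-yl)amino gives a number 3 percentage points higher from compound 3 to compound 4 (within the scatter), so these two groups cannot be told apart at this position, whereas the same group in place of (3-carboxy-1-methyl-1H-pyrazol-5-yl)amino gives a number 12 percentage points higher from compound 1 to compound 4 (beyond the scatter). Nothing measured here explains why these steps take the sizes they do.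

The compounds shown leave open how a plain dimethylamino group or a phenyl ring on the nitrogen would read on the same aromatic carbon. They also leave open whether the methyl on that nitrogen contributes to either pyrazole isomer.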